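The compounds below may be only part of what the source reports. "The series", "measured", "known", "first", "only" and "open" are said of these compounds alone.

Of the compounds shown here, three have been measured in an assay on IMR-32 cells for displacement of a labelled ligand from corticotropin-releasing factor receptor 1 (Homo sapiens), read by scintillation counting, with a stated time of 2 h; a lower number here means a stronger inhibitor, a higher number a weaker inhibitor: compound 1 `CCOc1ccc(-c2nc(OC)c(NC(CC)CC)nc2C)c(Cl)c1` gives 5.9 nM, compound 2 `CCC(CC)Nc1nc(OC)c(-c2ccc(Cl)cc2Cl)nc1OC` gives 8.4 nM, and compound 3 `CCc1nc(-c2ccc(Cl)cc2Cl)c(OC)nc1NC(CC)CC` gives 8 nM.

Compound 2 has the highest number of the three, yet its gap to compound 3 and its gap to compound 1 both fall within the usual scatter, so no ordering among them can be claimed. Compound 4 `CCC(CC)Nc1nc(C)c(-c2ccc(Cl)cc2Cl)nc1OC` differs from compound 2 by methyl in place of methoxy on an aromatic carbon. Going by the values given here, one measured step bears directly on this change: a 1.1-fold lower number from compound 2 to compound 3 (0.02 log units; within the scatter), where an ethyl replaced the same methoxy and left the number essentially unchanged. A smaller methyl in place of that methoxy is therefore expected to behave alike, giving a 1.1-fold lower number from compound 2 to compound 4 (0.02 log units; within the scatter) in this assay. Compound 4 is estimated at 8 nM, with a range from 3 nM to 20 nM.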

Compound 4, inhibition constant: 4.3 nM
Compound 4: middle estimate off by 1.9-fold (0.27 log units), on the high side; the range from low to high includes it.
By their numbers in this assay, from the lowest: compounds 4, 1, 3 and 2 (each within the scatter of the next).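

In the shared core, the step from methoxy to methyl ortho to a 2,4-dichlorophenyl group is a 2.0-fold lower number from compound 2 to compound 4 (0.29 log units; within the scatter), so this position accepts a methyl without a change that can be told from the scatter. With that methyl kept, chloro in place of ethoxy on an aromatic carbon gives a 1.4-fold lower number from compound 1 to compound 4 (0.14 log units; within the scatter), which also shows no readable change. Nothing here explains either result. The compounds shown leave open whether this position would also accept an amine, a nitrile or a longer chain such as propyl.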